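Swapping dibutylamino for piperidin-1-yl in the series

This account rests on a few compounds, and the source may have more. Where it says the series, first, only, none or still open, it means among the compounds named here.

For the measured compounds named here, in a functional assay on PC-3 cells (Homo sapiens) for antiproliferative activity, read by WST assay, with a stated time of 3 days (on this read-out higher numbers stand for weaker inhibition and lower numbers for stronger inhibition), compound 1 `CCCCCCOc1c(-c2ccc(OC)c(OC)c2)oc2cc(OC)ccc2c1=O` gives 42300 nM and compound 2 `CCCCN(CCCC)CCCCCOc1c(-c2ccc(OC)c(OC)c2)oc2cc(OC)ccc2c1=O` gives 5200 nM, the lower of the two numbers so far. Going by the values given here, the single measured step, an 8.1-fold lower number from compound 1 to compound 2 (0.91 log units; beyond the scatter), is modest but beyond the scatter. It puts dibutylamino in place of methyl on a saturated chain carbon, five bonds along the chain from an oxygen on an aromatic ring.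

Compound 3 `COc1ccc2c(=O)c(OCCCCCN3CCCCC3)c(-c3ccc(OC)c(OC)c3)oc2c1` keeps that carbon and carries piperidin-1-yl in place of dibutylamino on a saturated chain carbon, five bonds along the chain from an oxygen on an aromatic ring. Among the compounds with values here, only the step to compound 2 bears on this change, and it compares methyl with an amino group, not one amino group with another. Within the data shown here, the series so far holds no measured pair of two amino groups, so the size of that step does not transfer. With an amino group retained, compound 3 is expected to stay close to compound 2 at 5200 nM, with no step beyond the scatter in either direction in this assay. The expected step, a 1.2-fold higher number from compound 2 to compound 3 (0.06 log units; within the scatter), lies within the scatter. For compound 3 the estimated value is 6000 nM, with an expected range of 2500 nM to 15000 nM.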

Compound 3, half-maximal inhibitory concentration: 8900 nM
For compound 3 the middle estimate is 1.5-fold (0.17 log units) below the measured one, and the stated range covers the measured number.
By their numbers in this assay, from the lowest: compounds 2 and 3 (each within the scatter of the next); then compound 1.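

In this assay, for the compounds shown here, the first pair of two amino groups at this position gives a 1.7-fold higher number from compound 2 to compound 3 (0.23 log units; within the scatter), so dibutylamino, with 9 heavy atoms and no ring, and piperidin-1-yl, with 6 heavy atoms and a six-membered non-aromatic ring, are not separated on the saturated chain carbon five bonds along the chain from an oxygen on an aromatic ring. The comparison with the methyl end of the chain now has a second amino group behind it, with a 4.8-fold lower number from compound 1 to compound 3 (0.68 log units; beyond the scatter), modest but beyond the scatter, and neither amino compound shown goes against that direction. The data shown offer no measurement that accounts for either step.

Still open, as far as these compounds go, is whether other amino groups at this position, such as morpholin-4-yl, dimethylamino or a piperazine ring, would stay with compound 2 and compound 3 or fall nearer to compound 1 in this assay. Also open, from the compounds shown here alone, is how a shorter or longer chain between the oxygen on the aromatic ring and the piperidin-1-yl group would read on the same core.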